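The source may hold more compounds than are shown below. What is called first, only, known or untested is meant among the compounds shown, and "the series" means these compounds.

Measured compounds in an assay on CHO cells for displacement of a labelled ligand from Substance-P receptor (Homo sapiens), in the presence of a further agent that is not named here; a lower number here means a stronger inhibitor, a higher number a weaker inhibitor:
- compound 1, `C[C@@H](O[C@H]1CN2C(=O)C=C(c3ccc(F)cc3)CC2[C@@H]1c1ccc(F)cc1)c1cc(C(F)(F)F)cc(C(F)(F)F)c1`: 100 nM
- compound 2, `C[C@@H](O[C@H]1CN2C(=O)C=C(c3cnn(C)c3)CC2[C@@H]1c1ccc(F)cc1)c1cc(C(F)(F)F)cc(C(F)(F)F)c1`: 5.4 nM
- compound 3, `CCc1noc(C2=CC(=O)N3C[C@H](O[C@H](C)c4cc(C(F)(F)F)cc(C(F)(F)F)c4)[C@@H](c4ccc(F)cc4)C3C2)n1`: 27 nM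

In this assay compound 3 holds the second highest of the three numbers. Its nearest neighbour is compound 1, with the step of a 3.7-fold lower number from compound 1 to compound 3 (0.57 log units; beyond the scatter); furthest is compound 2, with the step of a 5.0-fold higher number from compound 2 to compound 3 (0.70 log units; beyond the scatter). All three compounds share one core and differ only in the group on a double-bonded ring carbon.

Compound 4, `C[C@@H](O[C@H]1CN2C(=O)C=C(C3=CCOCC3)CC2[C@@H]1c1ccc(F)cc1)c1cc(C(F)(F)F)cc(C(F)(F)F)c1`, keeps that core and differs from compound 3 in the same place: a group of 6 heavy atoms (5 carbon, 1 oxygen; one six-membered non-aromatic ring with 1 hetero atom) in place of a group of 7 heavy atoms (4 carbon, 2 nitrogen, 1 oxygen; one five-membered aromatic ring with 3 hetero atoms), on a double-bonded ring carbon. The measured steps that bear on this are the three exchanges at this position, a 19-fold lower number from compound 1 to compound 2 (1.27 log units; beyond the scatter), a 3.7-fold lower number from compound 1 to compound 3 (0.57 log units; beyond the scatter) and a 5.0-fold higher number from compound 2 to compound 3 (0.70 log units; beyond the scatter), which show that the group on this carbon moves the number by modest to large amounts in both directions. Within the data shown here, none of the measured groups is a six-membered non-aromatic ring, so no step gives a direct read on the entering group; the spread seen so far sets the range rather than the direction. The step of a 1.1-fold higher number from compound 3 to compound 4 (0.05 log units; within the scatter) is therefore expected to be small, within the scatter, with a wide range. For compound 4 the estimate in this assay is 30 nM, between 8 nM and 120 nM.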

Compound 4, half-maximal inhibitory concentration: 9.6 nM
Beside the measured number, compound 4's estimate is 3.1-fold (0.49 log units) above it; the measured number falls inside the stated range.
By their numbers in this assay, from the lowest: compounds 2 and 4 (each within the scatter of the next); then compound 3; then compound 1.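

In this assay, the six-membered non-aromatic ring with 1 hetero atom is the only group at this double-bonded ring carbon that is not an aromatic ring, and it still gives a 2.8-fold lower number from compound 3 to compound 4 (0.45 log units; beyond the scatter) and a 10-fold lower number from compound 1 to compound 4 (1.02 log units; beyond the scatter), so among the compounds shown an aromatic ring is not required here for a low number. With a 1.8-fold higher number from compound 2 to compound 4 (0.25 log units; within the scatter), which lies within the scatter, this ring and 1-methyl-1H-pyrazol-4-yl cannot be told apart, while the 4-fluorophenyl of compound 1 now carries the weakest result against all three other groups, each of which has hetero atoms in its ring. No measurement at hand accounts for these differences.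

Open, on these data alone, is what the ring oxygen and the double bond of the entering group each contribute: a tetrahydropyran-4-yl ring without the double bond and a cyclohexenyl ring of carbon only would separate the two. Also open, as far as these compounds go, is how a piperidine ring, an amine or a carboxylic acid on this carbon would read in this assay.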